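Sulfamoyl in place of hydroxy on the shared core

This account rests on a few compounds, and the source may have more. Where it says the series, first, only, none or still open, it means among the compounds named here.

Among the compounds with values here, in a functional assay on Ehrlich cells (Mus musculus) for inhibition (on this read-out lower numbers stand for stronger inhibition and higher numbers for weaker inhibition), compound 2 `O=C(O)c1cnc2cc(O)ccc2c1O` gives 912000 nM, the highest of the two numbers so far. Compound 1 `O=C(O)c1cnc2cc(OCc3c(Cl)c(Cl)c(Cl)c(Cl)c3Cl)ccc2c1O` gives 42700 nM, lower by a gap beyond the scatter. Compound 3 `NS(=O)(=O)c1ccc2c(O)c(C(=O)O)cnc2c1` carries sulfamoyl in place of hydroxy on an aromatic carbon. Within the data shown here, no measured pair isolates a change at one place, so no step beyond the scatter is expected in this assay, with a slight lean towards a lower number. The estimated step is a 1.5-fold lower number from compound 2 to compound 3 (0.18 log units; within the scatter). For compound 3, the expected value is 600000 nM, with an estimated range of 200000 nM to 1500000 nM.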

Compound 3, half-maximal inhibitory concentration: 3390000 nM
For compound 3 the middle estimate is 5.7-fold (0.75 log units) below the measured one; the whole stated range lies below it.
By their numbers in this assay, from the lowest: compound 1; then compound 2; then compound 3.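

In this assay, sulfamoyl in place of hydroxy on this aromatic carbon gives a 3.7-fold higher number from compound 2 to compound 3 (0.57 log units; beyond the scatter) and so moves towards weaker inhibition. Within the data shown here, this is the first reading of a change at this carbon alone, and on this single pair hydroxy is the better of the two groups, though both numbers remain high. Nothing on hand accounts for the step.

From the compounds shown here alone, whether an amine or a methoxy group on the same carbon would give a lower number stays open. One pair also cannot show whether the direction holds for other replacements of hydroxy.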